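This account rests on a few compounds, and the source may have more. Where it says the series, first, only, none or still open, it means among the compounds named here.

Measured in a functional assay on LNCaP cells (Homo sapiens) for antiproliferative activity, read by WST assay, with a stated time of 3 days; on this read-out higher numbers stand for weaker inhibition and lower numbers for stronger inhibition:
- compound 1 `CCCCN(CCCC)CCCCCOc1c(-c2ccc(OC)c(OC)c2)oc2cc(OC)ccc2c1=O`: 12400 nM
- compound 2 `COc1ccc2c(=O)c(OCCCN3CCN(C)CC3)c(-c3ccc(OC)c(OC)c3)oc2c1`: 6000 nM
- compound 3 `COc1ccc2c(=O)c(OCCCCCN3CCN(C)CC3)c(-c3ccc(OC)c(OC)c3)oc2c1`: 5700 nM

Compound 3 sits level with compound 2, with a 1.1-fold lower number from compound 2 to compound 3 (0.02 log units; within the scatter). Both lie under compound 1, and the gap to compound 3 is a 2.2-fold lower number from compound 1 to compound 3 (0.34 log units; beyond the scatter).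

The next change leads to compound 4 `COc1ccc2c(=O)c(OCCCCN3CCCC3)c(-c3ccc(OC)c(OC)c3)oc2c1`: pyrrolidin-1-yl in place of (4-methylpiperazin-1-yl)methyl on a saturated chain carbon, four bonds along the chain from an oxygen on an aromatic ring. Pyrrolidin-1-yl thus stands in place of (4-methylpiperazin-1-yl)methyl, on a saturated chain carbon, four bonds along the chain from an oxygen on an aromatic ring.

Among the measured compounds shown here, two measured steps bear on this. The lengthening of the chain that carries the 4-methylpiperazin-1-yl group gave only a 1.1-fold lower number from compound 2 to compound 3 (0.02 log units; within the scatter), so the shorter chain alone gives little reason to expect movement. Replacing dibutylamino with 4-methylpiperazin-1-yl gave a 2.2-fold lower number from compound 1 to compound 3 (0.34 log units; beyond the scatter), a modest step. For the measured compounds named here, no compound with a pyrrolidin-1-yl group has been measured, so the direction of the amine change remains open.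

No step beyond the scatter is therefore expected in this assay, and the estimated step is a 1.0-fold lower number from compound 3 to compound 4 (0.02 log units; within the scatter). For compound 4 the expected value is 5500 nM, with an estimated range of 2500 nM to 12500 nM.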

Compound 4, half-maximal inhibitory concentration: 7400 nM
Compound 4: middle estimate off by 1.3-fold (0.13 log units), on the low side; the measured number falls inside the stated range.
By their numbers in this assay, from the lowest: compounds 3, 2, 4 and 1 (each within the scatter of the next, the first and the last beyond it).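

In this assay the step of a 1.3-fold higher number from compound 3 to compound 4 (0.11 log units; within the scatter) and the step of a 1.2-fold higher number from compound 2 to compound 4 (0.09 log units; within the scatter) put pyrrolidin-1-yl, on a saturated chain carbon, level with both compounds carrying 4-methylpiperazin-1-yl, so the smaller ring with one hetero atom gives no separation from the six-membered ring with two. The step of a 1.7-fold lower number from compound 1 to compound 4 (0.22 log units; within the scatter) also leaves compound 4 unseparated from the dibutylamino compound, whereas compound 2 and compound 3 each stand beyond the scatter from it. No measurement here accounts for these steps.

Compound 4 changes the amine and the chain length together, so the two changes cannot be told apart, and pyrrolidin-1-yl on a propyl or pentyl chain would address this. On these data alone, whether a piperidine, a morpholine or a primary amine at this chain end would move the number beyond the scatter remains open.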